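Lengthening the Ethyl Chain of Compound 1

The compounds below may be only part of what the source reports. "The series", "measured", "known", "first", "only" and "open" are said of these compounds alone.

Measured compounds:
compound 1 `CCn1c(=O)n(C2OC(CO)[C@@H](O)[C@H]2O)c2nc(N)nc(O)c21` — 82%
compound 2 `C=CCn1c(=O)n(CCCCO)c2nc(N)nc(O)c21` — 12%
compound 3 `C=CCn1c(=O)n(Cc2ccccc2)c2nc(N)nc(O)c21` — 25%

In a functional assay on the whole organism (B cells) with Mus musculus as the target (on this read-out lower numbers stand for smaller maximal responses and higher numbers for larger maximal responses), compound 1 stands highest of the three, with compound 3 and compound 2 both lying beyond the scatter below it. Compound 4 `CCCCCCCCCCn1c(=O)n(C2OC(CO)[C@@H](O)[C@H]2O)c2nc(N)nc(O)c21` differs from compound 1 by octyl in place of hydrogen on a saturated chain carbon, two bonds along the chain from an aromatic nitrogen. Going by the values given here, the only measured step, a number 13 percentage points higher from compound 2 to compound 3 (beyond the scatter), concerns a different part of the shared core, so no measured step bears directly on this change. The added chain is sizeable, so some shift is plausible, but its direction cannot be read from these data. Compound 4 is therefore expected to show a number 27 percentage points lower from compound 1 to compound 4 (beyond the scatter), with wide uncertainty. Compound 4 is estimated at 55%, within a range of 15% to 95%.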

Compound 4, largest response reached (reported as maximal response), in percent of the reference or control that the assay uses: 0%
Compound 4: the middle estimate sits 55 percentage points above what was measured; measured number outside the range, below it.
By their numbers in this assay, from the lowest: compound 4; then compound 2; then compound 3; then compound 1.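

The ethyl chain of compound 1 proves not to be a neutral place to build on: in this assay, lengthening ethyl to decyl gives a number 82 percentage points lower from compound 1 to compound 4 (beyond the scatter). Going by these compounds alone, this is the first measured change at this position, and compound 4 gives 0%, so the change can remove the response entirely. Nothing available explains this loss.

Open, as far as these compounds go, is how the response changes with intermediate lengths, such as a butyl chain in place of ethyl. Also open, from the compounds shown here alone, is whether a chain bearing an amine or a carboxylic acid would keep the response.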